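Compound 1 and its untested 4-(1-methylethenyl)phenyl analogue

The source may report more compounds than this note shows. Statements on the series, on what has been measured and on what is new or still open speak of the compounds shown alone.

Measured so far in a functional assay on HL-60 cells (Homo sapiens) for inhibition, read by MTT assay, with a stated time of 72 h; a lower number here means a stronger inhibitor, a higher number a weaker inhibitor
- compound 1 `Cc1nc(-c2ccccc2)c(C(=O)N2CCN(c3cccc(Cl)c3Cl)CC2)o1` gives 133 nM
- compound 2 `Cc1nc(-c2ccc(Cl)cc2)c(C(=O)N2CCN(c3cccc(C(=O)C(C)C)c3)CC2)o1` gives "not active" (no number reported)

Compound 1 stands alone on the numbers, as compound 2 yielded no figure. Compound 3 `C=C(C)c1ccc(N2CCN(C(=O)c3oc(C)nc3-c3ccccc3)CC2)cc1` has not yet been measured. It keeps the core of compound 1 and differs by 4-(1-methylethenyl)phenyl in place of 2,3-dichlorophenyl on an amine nitrogen in a ring, with 4-(1-methylethenyl)phenyl in place of 2,3-dichlorophenyl on an amine nitrogen in a ring.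

Within the data shown here, no measured pair in this set differs in one place, so no direct precedent exists for this change. Compound 2 ("not active" (no number reported)) shows that activity in this assay is not kept by every member of the set. A move toward weaker inhibition is therefore expected, with an estimated 3.8-fold higher number from compound 1 to compound 3 (0.58 log units; beyond the scatter) that is more likely than not to exceed the scatter. For compound 3 the estimated value is 500 nM, with an expected range from 100 nM to 2500 nM.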

Compound 3, half-maximal inhibitory concentration: "not active" (no number reported)
Compound 3: no number reported, and the estimate cannot be compared.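

No new step can be read: in this assay compound 3 carries no number, and it cannot be set against compound 1 at 133 nM. Going by these compounds, how far 4-(1-methylethenyl)phenyl in place of 2,3-dichlorophenyl shifts inhibition stays open. No supporting data bear on this result.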